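A few compounds are considered here, and "the series" means these few. Any claim that something is new, unique, unknown or untested is made for them only; others in the source may bear on it.

Compound 1 `COc1ccccc1/C=C1\CCC/C(=C\c2cccc(OC)c2OC)C1=O`, tested in a functional assay on SW-620 cells (Homo sapiens) for cytotoxicity, read by MTT assay, with a stated time of 72 h (a higher number here means a weaker inhibitor, a lower number a stronger inhibitor), gives only a limit, > 20000 nM. Compound 2 `COc1ccc(/C=C2\CCC/C(=C\c3ccccc3Cl)C2=O)cc1OC` gives 7100 nM in this assay. Within the data shown here, that is the only actual number among the values shown; the other entry is a limit (the limit of > 20000 nM in this assay, at which 1 of the 2 values shown sits). Compound 3 `COc1ccc(/C=C2\CCC/C(=C\c3ccccc3Br)C2=O)cc1OC` has not yet been measured and differs from compound 2 by bromo in place of chloro on an aromatic carbon. Among the measured compounds shown here, no measured pair shows this change, so no measured step sizes it. The step from compound 2 to compound 3 is expected to be small, within the usual scatter in either direction, a 1.2-fold lower number from compound 2 to compound 3 (0.07 log units; within the scatter). Compound 3 is therefore expected to give about 6000 nM, between 3000 nM and 14000 nM.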

Compound 3, half-maximal inhibitory concentration: 5300 nM
Beside the measured number, compound 3's estimate is 1.1-fold (0.05 log units) above it; the range from low to high includes it.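

The change from 2-chlorophenyl to 2-bromophenyl now has a measured size in this assay: a 1.3-fold lower number from compound 2 to compound 3 (0.13 log units; within the scatter). At this position on the shared core, the two halogens therefore read alike, which a single chloro compound could not show. Nothing measured here accounts for this result.

The compounds shown leave open whether a plain phenyl, without a halogen, would read the same. They also leave open how an amine or a carboxylic acid in this place would read.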